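A few compounds are considered here, and "the series" means these few. Any claim that something is new, unique, unknown or untested is made for them only; others in the source may bear on it.

Measured compounds:
- compound 1, `CCCCCCC#Cc1ccc(S(=O)(=O)Nc2cccc(-c3csc(NC(C)=O)n3)c2)cc1`: in a functional assay on A-375 cells (Homo sapiens) for antiproliferative activity, read by trypan blue exclusion, with a stated time of 48 h, tested at 10 uM (a higher number here means a weaker effect of the compound at the concentration tested, a lower number a stronger effect), compound 1 gives 5.8%
- compound 2, `CC(=O)Nc1nc(-c2cccc(NS(=O)(=O)c3ccc(C#CCCc4ccccc4)cc3)c2)cs1`: in this assay compound 2 gives < 1%, a limit of the assay rather than a number
- compound 3, `CCCCCC/C=C\c1ccc(S(=O)(=O)Nc2cccc(-c3csc(NC(C)=O)n3)c2)cc1`: in this assay compound 3 gives <= 1%, also a limit of the assay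

Compound 1 holds the only number among these three; the other two values are limits. The steps of a number at least 4.8 percentage points lower from compound 1 to compound 2 (that floor lies within the scatter) and a number at least 4.8 percentage points lower from compound 1 to compound 3 (that floor lies within the scatter) both change the chain on the aromatic carbon, and both stay within the scatter. Compound 4, `CCCCCCC#Cc1ccc(S(=O)(=O)Nc2cccc(-c3csc(NC)n3)c2)cc1`, differs from compound 1 at another place: methyl in place of acetyl on a nitrogen on an aromatic ring. Going by the values given here, no measured step touches this position, so nothing here points to a direction. With compound 1 already low and the scatter wide, the expected step of a number 0.2 percentage points higher from compound 1 to compound 4 (within the scatter) is none beyond the scatter. Compound 4 is therefore estimated at 6%, between 1% and 20%.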

Compound 4, a percentage reported as activity, at one concentration (the size of the read-out at that concentration, not a potency): 1.2%
Estimate against measurement, compound 4: 4.8 percentage points above; low and high end bracket the measured number.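

In this assay, going by these compounds alone, methylamino in place of acetamido gives a number 4.6 percentage points lower from compound 1 to compound 4 (within the scatter), the first measured step at this position. On the core of compound 1, the acetyl group can therefore give way to a methyl without the read-out moving beyond the scatter. Nothing measured here explains this result.

Going by these compounds, whether a free amine or a longer chain such as propyl on this nitrogen would also keep the read-out this low remains open. So does whether methylamino would behave the same way with the other chains on the aromatic carbon.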